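A few compounds are considered here, and "the series" means these few. Any claim that something is new, unique, unknown or untested is made for them only; others in the source may bear on it.

Compound 1 `O=[N+]([O-])c1cn2c(n1)OC[C@@H](OCc1cnn(-c3ccc(OC(F)(F)F)cc3)c1)C2` and compound 2 `O=[N+]([O-])c1cn2c(n1)OC[C@@H](OCc1nnn(-c3ccc(C(F)(F)F)cc3)n1)C2` are the two compounds measured. In an ADME assay on Vero cells (Chlorocebus sabaeus) for cytotoxicity, with a stated time of 72 h (a lower number here means a stronger inhibitor, a higher number a weaker inhibitor), compound 1 gives only a limit of the assay, > 128000 nM. In this assay compound 2 likewise gives only a limit of the assay, > 128000 nM.

For the measured compounds named here, compound 2 thus stands exactly where the one other value shown stands: at the limit, with no actual number behind it. Going by the values given here, because of the limit of > 128000 nM in this assay, at which 2 of the 2 values shown sit, no step between measured compounds can be drawn, and there is no measured change on which to rest.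

Compound 3 `O=[N+]([O-])c1cn2c(n1)OC[C@@H](OCc1nnn(-c3ccc(OC(F)(F)F)cc3)n1)C2` differs from compound 2 in one place: trifluoromethoxy in place of trifluoromethyl on an aromatic carbon. Among the compounds with values here, no measured step covers this change. With both shown values sitting at the limit, nothing points in either direction, and the expected step that the limit leaves unreadable from compound 2 to compound 3 is none beyond the scatter. Compound 3 is estimated in this assay at 150000 nM, within 64000 nM to 400000 nM, and it is expected most likely to be reported again only as a limit.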

Compound 3, half-maximal inhibitory concentration: > 128000 nM
Compound 3 gave a limit, no number; the forecaster's own chance of this, stated with the estimate: 85%; the middle value lies beyond the limit too.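

No new step can be read between compound 2 and compound 3 in this assay, because both give only a limit of the assay: the limit of > 128000 nM in this assay, at which 3 of the 3 values shown sit.

The compounds shown leave open what actual number stands behind that limit for any of them, and so whether trifluoromethoxy in place of trifluoromethyl on an aromatic carbon makes any difference in this assay.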